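Lengthening the Chain on the Carbonyl of Compound 3

This account rests on a few compounds, and the source may have more. Where it says the series, first, only, none or still open, it means among the compounds named here.

Among the measured compounds shown here, in an ADME assay on L02 cells (Homo sapiens) for cytotoxicity, read by MTT assay, with a stated time of 72 h (on this read-out lower numbers stand for stronger inhibition and higher numbers for weaker inhibition), compound 3 (`C=CC(=O)Nc1cccc(Oc2nc(Nc3cccc(OC)c3)nc3c2CSCC3)c1`) gives 48900 nM, the only actual number among the measured compounds. Compound 1 (`C=CC(=O)Nc1cccc(Oc2nc(Nc3ccn(C)n3)nc3c2CSCC3)c1`) gives > 50000 nM, which is a limit of the assay. Compound 2 (`C=C(C)C(=O)Nc1cccc(Oc2nc(Nc3ccn(C)n3)nc3c2CSCC3)c1`) gives > 50000 nM, also a limit.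

Compound 4 (`CC/C=C/C(=O)Nc1cccc(Oc2nc(Nc3cccc(OC)c3)nc3c2CSCC3)c1`) carries but-1-en-1-yl in place of vinyl on a carbonyl carbon. For the measured compounds named here, the nearest precedent changes the same chain, yet a step that the two limits leave unreadable from compound 1 to compound 2 gives no size. A change to a different group, an at least 1.0-fold lower number from compound 1 to compound 3 (0.00 log units; that floor lies within the scatter), gives only a floor within the scatter. Neither measured step points to a real shift in this assay, so none beyond the scatter is expected. The expected step runs a 1.0-fold higher number from compound 3 to compound 4 (0.01 log units; within the scatter). For compound 4 the estimated value is 50000 nM, with an expected range of 25000 nM to 100000 nM.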

Compound 4, half-maximal inhibitory concentration: > 50000 nM
Compound 4: a limit, no number; the forecaster's own chance of this, stated with the estimate: 55%; the middle value lies on the limit itself.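

Among the compounds shown here, replacing vinyl with but-1-en-1-yl on the carbonyl carbon gives an at least 1.0-fold higher number from compound 3 to compound 4 (0.00 log units; that floor lies within the scatter), the first step on this chain that can be read at all, though only as a floor. In this assay, compound 4 gives > 50000 nM, which is a limit and not a number. The true size of the step therefore stays hidden, and no shift beyond the scatter can be claimed because the value rests on a shared ceiling: the limit of > 50000 nM in this assay, at which 3 of the 4 values shown sit.

The compounds shown leave open whether an amine on this chain, or a still longer chain, would give a real number in this assay. They also leave open how a carboxylic acid at this place would read.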